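This account rests on a few compounds, and the source may have more. Where it says the series, first, only, none or still open, it means among the compounds named here.

Measured so far in a functional assay for inhibition of sodium/hydrogen exchanger (Oryctolagus cuniculus); on this read-out lower numbers stand for stronger inhibition and higher numbers for weaker inhibition:
compound 1 `Cc1cc(C)c(S(C)(=O)=O)cc1C(=O)N=C(N)N` gives 11 nM
compound 2 `Cc1cc(Br)c(C(=O)N=C(N)N)cc1S(C)(=O)=O` gives 70 nM

Among the compounds with values here, compound 1 holds the lowest of the two numbers; its nearest neighbour is compound 2, reached by a 6.4-fold higher number from compound 1 to compound 2 (0.80 log units; beyond the scatter), the only step in hand, made by putting bromo in place of methyl on an aromatic carbon.

Compound 3 `Cc1cc(-c2ccc(Cl)cc2Cl)c(S(C)(=O)=O)cc1C(=O)N=C(N)N` is not yet measured. Against compound 1 it differs as follows: 2,4-dichlorophenyl in place of methyl on an aromatic carbon. This is a change at the same aromatic carbon that the step to compound 2 touches, and that step went to a higher number, beyond the scatter. Within the data shown here, a far larger group enters here, so the one step in hand gives only direction, not size, and the result could fall anywhere from near compound 1 to well beyond compound 2.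

Expectation for compound 3: a higher number than compound 1, with a 5.5-fold higher number from compound 1 to compound 3 (0.74 log units; beyond the scatter), estimated at 60 nM within 15 nM to 300 nM.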

Compound 3, half-maximal inhibitory concentration: 42 nM
The estimate for compound 3 lay 1.4-fold (0.15 log units) above the measured number; the measured number falls inside the stated range.
By their numbers in this assay, from the lowest: compound 1; then compounds 3 and 2 (each within the scatter of the next).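

Putting 2,4-dichlorophenyl in place of methyl on this aromatic carbon, ortho to a methylsulfonyl group, gives a 3.8-fold higher number from compound 1 to compound 3 (0.58 log units; beyond the scatter) in this assay and so shows that an aromatic ring carrying two chlorines is accepted here at a modest cost. Compound 3 and compound 2 lie within the scatter of each other, although 8 heavy atoms enter in compound 3, so across these three compounds the number does not simply climb with the size of the group. Nothing available bears on why this change costs what it does.

Going by these compounds, both replacements of methyl so far end at a higher number beyond the scatter, so it remains open whether any group on this carbon can match methyl. Also open, on these data alone, is how an unsubstituted phenyl, an amine or a carboxylic acid would read here, and what each chlorine contributes.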